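Adding a hydroxy group to the aniline of compound 1

The source may report more compounds than this note shows. Statements on the series, on what has been measured and on what is new or still open speak of the compounds shown alone.

For the measured compounds named here, the two compounds measured so far share one core and differ only in the aryl ring on the amine. Compound 1, `C#CCSc1nc(Nc2ccccc2)c2ccncc2n1`, gives 16200 nM in a functional assay on MGC-803 cells (Homo sapiens) for inhibition, read by MTT assay, with a stated time of 72 h (on this read-out higher numbers stand for weaker inhibition and lower numbers for stronger inhibition), the highest of the two numbers. Compound 2, `C#CCSc1nc(Nc2cc(OC)c(OC)c(OC)c2)c2ccncc2n1`, gives 5680 nM in this assay, a number that lies beyond the usual scatter from that of compound 1. Compound 3, `C#CCSc1nc(Nc2ccccc2O)c2ccncc2n1`, is the next compound to be tested. It differs from compound 1 by a single change: hydroxy in place of hydrogen on an aromatic carbon. Going by the values given here, no measured pair shows what such a hydroxy group does, so nothing here points firmly in either direction. The change is small and sits ortho to a large group; a step no larger than the scatter, in either direction, is the most plausible outcome. The number estimated for compound 3 in this assay is 12000 nM, with a range from 3000 nM to 45000 nM, which means an expected step of a 1.4-fold lower number from compound 1 to compound 3 (0.13 log units; within the scatter).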

Compound 3, half-maximal inhibitory concentration: 21000 nM
Beside the measured number, compound 3's estimate is 1.8-fold (0.24 log units) below it, and the stated range covers the measured number.
By their numbers in this assay, from the lowest: compound 2; then compounds 1 and 3 (each within the scatter of the next).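

In this assay, for the compounds shown here, the swap of phenyl to 2-hydroxyphenyl gives a 1.3-fold higher number from compound 1 to compound 3 (0.11 log units; within the scatter) and is the first step that changes a single place. It shows that a hydroxy group on this aromatic carbon, ortho to a large group, leaves compound 3 indistinguishable from compound 1 on this read-out, so at this position the group neither clearly strengthens nor clearly weakens inhibition. Why the two numbers fall so close together cannot be said, as no supporting data bear on this result.

Going by these compounds, whether a hydroxy group elsewhere on the same ring would behave alike remains open. So does whether an amine or a carboxylic acid at this same position would move the number beyond the usual scatter.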